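The source may report more compounds than this note shows. Statements on the series, on what has been measured and on what is new or still open speak of the compounds shown alone.

Within the data shown here, compound 2 `c1ccc2c(-c3cn4ccnc4c(-c4ccc5ncn(C6CCCCC6)c5c4)n3)cccc2c1` stands lowest of the two numbers so far: in a functional assay on HCT-15 cells (Homo sapiens) for inhibition, read by sulforhodamine B assay, with a stated time of 48 h, tested at 10 uM (on this read-out lower numbers stand for less inhibition and higher numbers for more inhibition at the one concentration tested (going by the name of the read-out)), compound 2 gives 4.46%, while compound 1 `O=Cc1ccc(-c2cn3ccnc3c(-c3ccc4ncn(C5CCCCC5)c4c3)n2)cc1` gives 49.1% in this assay. Among the measured compounds shown here, the only measured step bearing on the new compound is a number 44.6 percentage points lower from compound 1 to compound 2 (beyond the scatter), the reverse of which resembles the move to compound 3 `Brc1ccc(-c2cn3ccnc3c(-c3ccc4ncn(C5CCCCC5)c4c3)n2)cc1`: 4-bromophenyl in place of naphthalen-1-yl on an aromatic carbon. A 4-bromophenyl is not a 4-formylphenyl, so the full reversal need not be recovered, but a step upward beyond the scatter is expected, a number 30.5 percentage points higher from compound 2 to compound 3 (beyond the scatter). Compound 3 is therefore estimated at 35%, within a range of 10% to 60%, in this assay.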

Compound 3, a percentage reported as inhibition, at one concentration (the size of the read-out at that concentration, not a potency): 35.8%
Compound 3: the middle estimate sits 0.8 percentage points below what was measured, and the stated range covers the measured number.
By their numbers in this assay, from the lowest: compound 2; then compound 3; then compound 1.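

In this assay, a single ring carrying bromo at this aromatic carbon stands well clear of naphthalen-1-yl, a number 31.3 percentage points higher from compound 2 to compound 3 (beyond the scatter). Bromo in place of formyl costs less, a number 13.3 percentage points lower from compound 1 to compound 3 (beyond the scatter), so among these compounds inhibition at this position does not depend on the carbonyl, though compound 1 stays ahead of compound 3. No evidence on hand accounts for either step. As far as these compounds go, whether the low value of compound 2 comes from its second aromatic ring or from how naphthalen-1-yl is attached stays open. So does what 4-aminophenyl or 4-carboxyphenyl would give in place of 4-bromophenyl.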